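A few compounds are considered here, and "the series" means these few. Any claim that something is new, unique, unknown or untested is made for them only; others in the source may bear on it.

Series notes. Compound 1 `O=C(Nc1ccccc1)c1c(NO)cc(-c2ccc(Cl)cc2)oc1=O` serves as the reference point of the set. In an ADME assay on Huh-7 cells (Homo sapiens) for cytotoxicity, read by a luciferase reporter and WST assay, with a stated time of 3 days (a higher number here means that more compound is tolerated, a lower number that less compound is tolerated), compound 1 gives 11000 nM. Compound 2 `Cc1ccc(-c2cc(NO)c(C(=O)Nc3ccccc3)c(=O)o2)cc1` differs from compound 1 by methyl in place of chloro on an aromatic carbon. In this assay compound 2 reaches only a limit of the assay, > 20000 nM. The resulting step is an at least 1.8-fold higher number from compound 1 to compound 2 (0.25 log units; that floor lies within the scatter). Compound 3 `O=C(NCCO)c1c(NO)cc(-c2ccc(Cl)cc2)oc1=O` carries a different core, the difference being (2-hydroxyethyl in place of phenyl on an amide-type nitrogen). In this assay compound 3 likewise reaches only a limit, > 20000 nM. The step here is an at least 1.8-fold higher number from compound 1 to compound 3 (0.25 log units; that floor lies within the scatter). Both limits sit at the same ceiling, (the limit of > 20000 nM in this assay, at which 2 of the 3 values shown sit), so neither step can be sized beyond its floor, and no order between compound 2 and compound 3 can be read from these numbers.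

Compound 4 `Cc1ccc(-c2cc(NO)c(C(=O)NCCO)c(=O)o2)cc1` has not yet been measured in this assay. It differs from compound 3 by methyl in place of chloro on an aromatic carbon; this is the same change as that made from compound 1 to compound 2, now applied on the core of compound 3. That earlier change carried the reference compound up to the ceiling, an at least 1.8-fold higher number from compound 1 to compound 2 (0.25 log units; that floor lies within the scatter), and compound 3 already stands at that ceiling on its own core. Compound 4 is therefore expected to give 30000 nM. The step expected for compound 4, a step that the limit leaves unreadable from compound 3 to compound 4, rests on the earlier step of an at least 1.8-fold higher number from compound 1 to compound 2 (0.25 log units; that floor lies within the scatter) together with the step of an at least 1.8-fold higher number from compound 1 to compound 3 (0.25 log units; that floor lies within the scatter), and the most likely outcome is that compound 4 again returns only a limit rather than a number.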

Compound 4, half-maximal cytotoxic concentration: > 20000 nM
Compound 4: no number, only a limit; the forecaster's own chance of this, stated with the estimate: 85%; the middle value is on the limit's open side.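

Compound 4 returns only a limit, so no size can be read for the steps from compound 3 to compound 4 or from compound 2 to compound 4, because all three compounds sit at the same ceiling: the limit of > 20000 nM in this assay, at which 3 of the 4 values shown sit.

The compounds shown leave open how far compound 2, compound 3 and compound 4 lie apart in this assay, and in what order.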